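The compounds below may be only part of what the source reports. "The series", "measured", "known", "first", "only" and "open" are said of these compounds alone.

Compound 1 `CCC1(Cc2ccccc2)OS(=O)(=O)C=C1OCc1ccc(F)cc1`: >= 50000 nM
Compound 2 `CC1(Cc2ccccc2)OS(=O)(=O)C=C1OCc1ccccc1`: > 400000 nM

Both results come from an ADME assay on HEL cells (Homo sapiens) for cytotoxicity, with a stated time of 3 days; on this read-out higher numbers stand for lower toxicity in this test and lower numbers for higher toxicity in this test. For compound 1 the value >= 50000 nM is a limit of the assay rather than a measured number. For compound 2 the value > 400000 nM is likewise a limit of the assay. Compound 1 therefore stands only at a limit, and the other value known here is a limit as well (the limit of > 400000 nM in this assay, at which 1 of the 2 values shown sits). The two compounds differ in more than one place, so their two values show only that both sit at limits.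

Compound 3 `C=CCOC1=CS(=O)(=O)OC1(CC)Cc1ccccc1` is not yet measured. It differs from compound 1 in one place: vinyl in place of 4-fluorophenyl on a saturated chain carbon bound to an oxygen on an unsaturated carbon. Among the compounds with values here, no step between measured compounds is known here, and no step beyond the usual scatter is expected in this assay. The estimate for compound 3 is 100000 nM, with a range from 30000 nM to 400000 nM. That estimate means an expected step that the limit leaves unreadable from compound 1 to compound 3 that stays within the scatter.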

Compound 3, minimum cytotoxic concentration: 80000 nM
Beside the measured number, compound 3's estimate is 1.3-fold (0.10 log units) above it; low and high end bracket the measured number.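

Compound 1 stands at >= 50000 nM, which is a limit of the assay and not a number. Within the data shown here, no step from compound 1 to compound 3 can be read. On these data alone, whether vinyl in place of 4-fluorophenyl changes the toxicity read-out at all, and in which direction, stays open.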